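The source may report more compounds than this note shows. Statements on the series, on what has been measured and on what is new or still open speak of the compounds shown alone.

In an ADME assay on L132 cells (Homo sapiens) for cytotoxicity, read by MTT assay, with a stated time of 48 h (a lower number here means a stronger inhibitor, a higher number a weaker inhibitor), compound 1 `C/C(=C\CC/C(C)=C/CC[C@@H]1[C@@]2(C)CCC(=O)C(C)(C)[C@H]2CC[C@@]1(C)O)CC/C=C(\C)C(=O)OCc1cn(-c2ccccc2)nn1` gives > 150000 nM, which is a limit of the assay and not a number. Among the measured compounds shown here, compound 2 `C/C(=C\CC/C(C)=C/CC[C@@H]1[C@@]2(C)CCC(=O)C(C)(C)[C@H]2CC[C@@]1(C)O)CC/C=C(\C)C(=O)OCc1cn(-c2ccc(C(C)(C)C)cc2)nn1` gives 65800 nM, the only actual number so far. Compound 3 `C/C(=C\CC/C(C)=C/CC[C@@H]1[C@@]2(C)CCC(=O)C(C)(C)[C@H]2CC[C@@]1(C)O)CC/C=C(\C)C(=O)OCc1cn(-c2cccc(O)c2)nn1` has 3-hydroxyphenyl in place of 4-(tert-butyl)phenyl on an aromatic nitrogen. For the measured compounds named here, only one measured step bears on this change: an at least 2.2-fold lower number from compound 1 to compound 2 (0.35 log units; beyond the scatter), which came with tert-butyl in place of hydrogen on an aromatic carbon. Going by the values given here, compound 3 has no tert-butyl, so part of that step is expected to be undone, while the hydroxyl has no measured step of its own. The expected change is modest and towards a higher number in this assay, namely a 1.6-fold higher number from compound 2 to compound 3 (0.20 log units; within the scatter). For compound 3 the estimated value is 105000 nM, with an expected range of 45000 nM to 220000 nM.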

Compound 3, half-maximal inhibitory concentration: 146000 nM
Compound 3: the middle estimate sits 1.4-fold (0.14 log units) below what was measured; the measured number falls inside the stated range.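

In this assay, 3-hydroxyphenyl in place of 4-(tert-butyl)phenyl on the aromatic nitrogen gives a 2.2-fold higher number from compound 2 to compound 3 (0.35 log units; beyond the scatter), so the tert-butyl gain seen earlier does not carry over to this hydroxylated ring. Hydroxy in place of hydrogen on the phenyl ring gives an at least 1.0-fold lower number from compound 1 to compound 3 (0.01 log units; that floor lies within the scatter), so this step shows no clear separation between the hydroxylated ring and the plain phenyl ring. The reading for compound 1 is a limit of the assay, and this restricts what that comparison can show: the limit of > 150000 nM in this assay, at which 1 of the 3 values shown sits.

The compounds shown leave open whether the hydroxy group would behave the same way at another position on the phenyl ring. They also leave open whether an amine or a carboxylic acid on that ring would lower the number as tert-butyl does.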